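The source may report more compounds than this note shows. Statements on the series, on what has been measured and on what is new or still open speak of the compounds shown alone.

Values in an ADME assay on microsomes from liver (Homo sapiens) for pharmacokinetics, read by LC-MS, using NADPH, with a stated time of 45 min, tested at 1 uM (a lower number here means slower removal, a higher number faster removal of the compound), for the compounds measured so far:
compound 1 `COc1cc(OCc2ccnc(N)n2)cc2sc(N[C@@H]3CCCC[C@H]3O)nc12` gives 10 mL/min/kg here
compound 2 `COc1cc(OCc2ccnc(N)n2)c(Cl)c2sc(N[C@H]3CCCC[C@@H]3O)nc12` gives 33 mL/min/kg here
compound 3 `CNC(=O)Nc1nccc(COc2cc(OC)c3nc(N[C@H]4CCCC[C@@H]4O)sc3c2)n1` gives 23 mL/min/kg here

Compound 3 lies within the usual scatter of compound 2, while compound 1 has a lower number, and that gap is beyond the scatter. Compound 4 `COc1cc(OCc2ccnc(Nc3cn[nH]c3)n2)cc2sc(N[C@H]3CCCC[C@@H]3O)nc12` has not yet been measured. It carries 1H-pyrazol-4-yl in place of methylcarbamoyl on a nitrogen on an aromatic ring. The same difference reads (methylcarbamoyl)amino to (1H-pyrazol-4-yl)amino, so one five-membered aromatic ring with 2 hetero atoms enters where no ring stood before.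

For the measured compounds named here, no two measured compounds differ in one place only, so nothing here shows directly what such a change does. With compound 3 at 23 mL/min/kg as the starting point, no step beyond the scatter is expected in this assay for this swap. The expected change is a 1.1-fold higher number from compound 3 to compound 4 (0.04 log units; within the scatter) and it stays within the scatter, with no firm direction. For compound 4 the estimated value is 25 mL/min/kg (expected range 11 mL/min/kg to 50 mL/min/kg).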

Compound 4, clearance: 32 mL/min/kg
Compound 4: middle estimate off by 1.3-fold (0.11 log units), on the low side; measured number inside the range.
By their numbers in this assay, from the lowest: compound 1; then compounds 3, 4 and 2 (each within the scatter of the next).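

For the compounds shown here, compounds 3 and 4 form the first pair here that differs in one place only, so this change at the nitrogen on an aromatic ring can now be read directly. In this assay, swapping methylcarbamoyl for 1H-pyrazol-4-yl gives a 1.4-fold higher number from compound 3 to compound 4 (0.14 log units; within the scatter), so a five-membered aromatic ring can enter where no ring stood before without a step beyond the scatter. No measurement shown here offers a reason for this result.

The compounds shown leave open whether an acetyl group, a plain methyl or a pyridin-4-yl ring on the same nitrogen would also stay within the scatter of compound 3. Going by these compounds, it also remains open whether the same swap would give a similar step on a core carrying chlorine, as compound 2 does.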